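Dropping a Fluoro Group: What Changes in Cell Toxicity

This account rests on a few compounds, and the source may have more. Where it says the series, first, only, none or still open, it means among the compounds named here.

Compound 1 `COc1ccc(C2=C(c3cc(OC)c(OC)c(OC)c3)C(=O)C(OC(C)=O)C2)cc1F` is one of two compounds tested in an ADME assay on ECV-304 cells (Homo sapiens) for cytotoxicity, read by MTT assay, with a stated time of 72 h (a lower number here means a stronger inhibitor, a higher number a weaker inhibitor), where compound 1 gives 41 ug/mL. Compound 2 `COCOc1cc(C2=C(c3cc(OC)c(OC)c(OC)c3)C(=O)CC2O[SiH2]C(C)(C)C)ccc1OC` gives 40 ug/mL in this assay, and the two values lie within the scatter of each other. Compound 3 `COc1ccc(C2=C(c3cc(OC)c(OC)c(OC)c3)C(=O)C(OC(C)=O)C2)cc1` differs from compound 1 in one place: hydrogen in place of fluoro on an aromatic carbon. For the measured compounds named here, no measured pair shows this kind of change, so the step in this assay is expected to be small, with no clear direction and probably not beyond the scatter; the estimated step is a 1.1-fold higher number from compound 1 to compound 3 (0.04 log units; within the scatter). Compound 3 is therefore expected to give about 45 ug/mL, within a range from 20 ug/mL to 95 ug/mL.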

Compound 3, half-maximal inhibitory concentration: 18 ug/mL
Beside the measured number, compound 3's estimate is 2.5-fold (0.40 log units) above it; measured number outside the range, below it.
By their numbers in this assay, from the lowest: compound 3; then compounds 2 and 1 (each within the scatter of the next).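

Going from 3-fluoro-4-methoxyphenyl to 4-methoxyphenyl gives a 2.3-fold lower number from compound 1 to compound 3 (0.36 log units; beyond the scatter) in this assay, so a change of one atom at this place on the aromatic ring is enough to move the result beyond the usual scatter. The lower number means that the compound without fluoro is the stronger inhibitor of this pair. Nothing shown here explains this step.

On these data alone, whether a chloro or a methyl group at the same place would give a number near that of fluoro or that of hydrogen remains open. So does whether the same step would appear on a different core.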